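A few compounds are considered here, and "the series" means these few. Any claim that something is new, unique, unknown or untested is made for them only; others in the source may bear on it.

Measured so far:
compound 1 `COc1ccccc1/C=C/C(=O)/C=C/c1ccc(OCc2cn(CCCOc3cc(=O)oc4ccccc34)nn2)c(OC)c1`: 57%
compound 2 `COc1cc(/C=C/C(=O)/C=C/c2ccco2)ccc1OCc1cn(CCCCOc2cc(=O)oc3ccccc23)nn1`: 43%

In a functional assay on COLO 205 cells (Homo sapiens) for inhibition, read by sulforhodamine B assay, with a stated time of 48 h, tested at 50 uM (a higher number here means more inhibition of growth at the concentration tested, a lower number less inhibition of growth), compound 1 gives 57%. Compound 2 gives 43%, the lower of the two numbers, and the gap to compound 1 lies beyond the scatter. Among the compounds with values here, no two measured compounds differ in a single place, so no step is known; the two values only show that compound 2 is the weaker of the pair.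

Compound 3 `COc1ccc(/C=C/C(=O)/C=C/c2ccc(OCc3cn(CCCCOc4cc(=O)oc5ccccc45)nn3)c(OC)c2)cc1` is not yet measured. It differs from compound 2 by 4-methoxyphenyl in place of furan-2-yl on a double-bonded chain carbon bound to a double-bonded chain carbon. Within the data shown here, with no comparable step on record, the expectation rests on the two values alone: a moderate upward move in this assay is expected for compound 3, toward the level of compound 1, with a wide range. The estimated step from compound 2 to compound 3 is a number 9 percentage points higher from compound 2 to compound 3 (within the scatter). Compound 3 is expected to give 52%, between 35% and 68%.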

Compound 3, percent growth inhibition at one concentration: 49%
The estimate for compound 3 lay 3 percentage points above the measured number; measured number inside the range.
By their numbers in this assay, from the lowest: compounds 2, 3 and 1 (each within the scatter of the next, the first and the last beyond it).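

In this assay, 4-methoxyphenyl in place of furan-2-yl on a double-bonded chain carbon bound to a double-bonded chain carbon gives a number 6 percentage points higher from compound 2 to compound 3 (within the scatter), the first step read in this series. This position therefore accepts a six-membered aromatic ring of carbon only, with its methoxy group and larger heavy-atom count, in place of a five-membered aromatic ring with a hetero atom, with no change in growth inhibition beyond the usual scatter at the single concentration tested. No supporting measurement bears on this result.

Still open, on these data alone, is whether a more different group here, such as 4-aminophenyl or 4-carboxyphenyl, would move the number beyond the scatter. Also open, as far as these compounds go, is whether this same exchange reads alike on a longer chain, or at concentrations other than the one tested.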